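A few compounds are considered here, and "the series" means these few. Any claim that something is new, unique, unknown or untested is made for them only; others in the source may bear on it.

Measured compounds:
compound 1, `CCOC(=O)c1cc(-c2cc(OC)c(OC)c(OC)c2)c(-c2ccc(OC)cc2)s1`, 8370 nM
compound 2, `CCOC(=O)c1cc(-c2cc(OC)c(OC)c(OC)c2)c(-c2ccc(OC)c([N+](=O)[O-])c2)s1`, 12700 nM
compound 3, `CCOC(=O)c1cc(-c2cc(OC)c(OC)c(OC)c2)c(-c2ccc3ccccc3c2)s1`, 1150 nM

All three were tested in a functional assay on HT-1080 cells (Homo sapiens) for antiproliferative activity, read by MTT assay, with a stated time of 72 h; on this read-out lower numbers stand for stronger inhibition and higher numbers for weaker inhibition. Compound 2 has the highest number of the three, with compound 1 nearest and compound 3 furthest. The two steps read a 1.5-fold higher number from compound 1 to compound 2 (0.18 log units; within the scatter) and an 11-fold lower number from compound 2 to compound 3 (1.04 log units; beyond the scatter). Compound 4, `CCOC(=O)c1cc(-c2cc(OC)c(OC)c(OC)c2)c(-c2ccc(OC)c(O)c2)s1`, has not yet been measured. It differs from compound 2 in one place: hydroxy in place of nitro on an aromatic carbon. The change sits on an aromatic carbon of a six-membered aromatic ring of carbon only, ortho to a methoxy group and meta to a large group.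

For the measured compounds named here, the only measured step touching the same position is the one from compound 1 to compound 2, nitro in place of hydrogen, and it stayed within the scatter. Going by the values given here, no measured compound carries a hydroxy group, so the effect of hydroxy entering is unknown. Removing nitro is therefore expected to return roughly the number of compound 1, and hydroxy is not assumed to move it beyond the scatter. Compound 4 is expected to show a 1.6-fold lower number from compound 2 to compound 4 (0.20 log units; within the scatter), which is no step beyond the scatter. The estimate for compound 4 is 8000 nM, within 3000 nM to 22000 nM.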

Compound 4, half-maximal inhibitory concentration: 3220 nM
The estimate for compound 4 lay 2.5-fold (0.40 log units) above the measured number, within the range that was stated.
By their numbers in this assay, from the lowest: compound 3; then compound 4; then compounds 1 and 2 (each within the scatter of the next).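

In this assay, for the compounds shown here, this position proves sensitive to what sits on it, which the nitro step alone did not show: hydroxy in place of nitro gives a 3.9-fold lower number from compound 2 to compound 4 (0.60 log units; beyond the scatter) and hydroxy in place of hydrogen gives a 2.6-fold lower number from compound 1 to compound 4 (0.41 log units; beyond the scatter) so hydroxy is the first group here to move the number beyond the scatter at this carbon. Even so, the 3-hydroxy-4-methoxyphenyl group does not match naphthalen-2-yl, as a 2.8-fold higher number from compound 3 to compound 4 (0.45 log units; beyond the scatter) shows. Nothing available explains why hydroxy acts in this way.

Going by these compounds, it remains open whether this gain is particular to hydroxy or would also appear with an amine or a second methoxy group on the same carbon. On these data alone, it is also open whether adding hydroxy to the naphthalen-2-yl group would lower the number further.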